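Swapping methyl for fluoro in a cytotoxicity series

The source may report more compounds than this note shows. Statements on the series, on what has been measured and on what is new or still open speak of the compounds shown alone.

Measured in a functional assay on SK-N-SH cells (Homo sapiens) for cytotoxicity, read by MTT assay, with a stated time of 24 h (on this read-out higher numbers stand for weaker inhibition and lower numbers for stronger inhibition), are these compounds
- compound 1 `Nc1cccn2cc(Cc3ccccc3)c(=O)nc12` gives 116000 nM as its value
- compound 2 `Cc1ccc(Cc2cn3cc(Cl)ccc3nc2=O)cc1` gives 860 nM as its value
- compound 3 `CC1(C)OC2O[C@@H](Cc3cn4ccccc4nc3=O)C(OCc3ccccc3)C2O1` gives > 1000000 nM as a limit

Compound 2 at 860 nM holds the lowest of the two numbers, and its gap to compound 1 lies beyond the scatter. The entry for compound 3 is a limit and not a number. Compound 4 `O=c1nc2ccc(Cl)cn2cc1Cc1ccc(F)cc1` remains unmeasured. It differs from compound 2 by fluoro in place of methyl on an aromatic carbon in one place, fluoro in place of methyl on an aromatic carbon, para to a large group. Going by the values given here, no measured pair shows such a swap, so the expectation rests on compound 2 at 860 nM alone. In this assay no change beyond the scatter is expected, in either direction. The expected 1.2-fold higher number from compound 2 to compound 4 (0.07 log units; within the scatter) is small. Compound 4 is estimated at 1000 nM within a range of 250 nM to 5000 nM for its reading.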

Compound 4, half-maximal inhibitory concentration: 9860 nM
Estimate against measurement, compound 4: 9.9-fold (0.99 log units) below, and the stated range ends below it.
By their numbers in this assay, from the lowest: compound 2; then compound 4; then compound 1. At a limit, above all of these: compound 3.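

At this place, on an aromatic carbon para to a large group, the change is far from neutral: fluoro in place of methyl gives an 11-fold higher number from compound 2 to compound 4 (1.06 log units; beyond the scatter) in this assay. Going by these compounds alone, this is the first step between compounds that differ in one place, so the earlier compounds could not show that the group here matters for this read-out. Nothing measured in the data at hand accounts for the step. The compounds shown leave open how a methoxy group or a carboxylic acid at this place would read.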